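The source may report more compounds than this note shows. Statements on the series, on what has been measured and on what is new or still open speak of the compounds shown alone.

Of the compounds shown here, three that share one core have been tested in a functional assay on HCT-116 cells (Homo sapiens) for inhibition, read by MTT assay, with a stated time of 48 h; on this read-out lower numbers stand for stronger inhibition and higher numbers for weaker inhibition. Compound 1 `CCCCC(=O)N(Cc1ccc(OC)c(O)c1)c1cc(OC)c(OC)c(OC)c1` gives 170 nM in this assay. Compound 2 `C/C=C/C(=O)N(Cc1ccc(OC)c(N)c1)c1cc(OC)c(OC)c(OC)c1` gives 300 nM in this assay. Compound 3 `COc1cc(NCc2cccc(O)c2)cc(OC)c1OC` gives 67700 nM in this assay. Of these three numbers, compound 1 has the lowest; the number of compound 2 lies within the usual scatter of repeated measurements, so the two cannot be told apart, whereas the number of compound 3 lies far beyond that scatter and is much higher than the other two.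

Compound 4 `COc1ccc(CN(C(=O)CCCCCl)c2cc(OC)c(OC)c(OC)c2)cc1O` has not yet been measured. It differs from compound 1 in a single place: chloro in place of hydrogen on a saturated chain carbon, four bonds along the chain from a carbonyl carbon. Among the measured compounds shown here, no pair of measured compounds that differ in only one place is available in this assay, so there is no directly comparable step to lean on. The step of a 1.2-fold higher number from compound 1 to compound 4 (0.07 log units; within the scatter) is expected to be small, in either direction, and not beyond the scatter. Compound 4 is therefore expected to give about 200 nM in this assay, with a range from 80 nM to 500 nM.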

Compound 4, half-maximal inhibitory concentration: 220 nM
Compound 4: the middle estimate sits 1.1-fold (0.04 log units) below what was measured, within the range that was stated.
By their numbers in this assay, from the lowest: compounds 1, 4 and 2 (each within the scatter of the next); then compound 3.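

Swapping hydrogen for chloro on a saturated chain carbon, four bonds along the chain from a carbonyl carbon, gives in this assay a 1.3-fold higher number from compound 1 to compound 4 (0.11 log units; within the scatter) and is the first comparison here between two compounds that differ in only one place. The earlier compounds shown here could not isolate a single change, but this pair can, and it shows that adding this one chlorine atom at this position produces no difference that can be separated from ordinary assay variation: compound 1 and compound 4 cannot be told apart on this read-out. No supporting measurement is available to explain why the two compounds read alike.

This single pair says nothing about other groups on the same carbon, such as an amine, a carboxylic acid or a longer chain, any of which could give a very different number. Also open, on these data alone, is whether chloro would read the same way on another carbon of this chain, or on a compound other than compound 1.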